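Swapping Iodine for Chlorine on the Fused Ring

This account rests on a few compounds, and the source may have more. Where it says the series, first, only, none or still open, it means among the compounds named here.

Measured compounds:
compound 1 `O=C1C(=O)N(CCCCCn2cc(COc3cc(=O)oc4ccccc34)nn2)c2ccccc21`, in a functional assay on THP-1 cells (Homo sapiens) for inhibition, read by sulforhodamine B assay, with a stated time of 48 h, tested at 50 uM (a lower number here means less inhibition of growth, a higher number more inhibition of growth at the concentration tested), compound 1 gives 69%
compound 2 `O=C1C(=O)N(CCCn2cc(COc3cc(=O)oc4ccccc34)nn2)c2ccc(I)cc21`, compound 2 gives 67%
compound 3 `O=C1C(=O)N(CCCCCn2cc(COc3cc(=O)oc4ccccc34)nn2)c2ccc([N+](=O)[O-])cc21`, compound 3 gives 37%

Compound 2 stands second highest of these three numbers. Its nearest neighbour is compound 1, within the usual scatter, and its furthest is compound 3, beyond it. Among the measured compounds shown here, the only single-place step measured is a number 32 percentage points lower from compound 1 to compound 3 (beyond the scatter), a nitro replacing hydrogen; no measured step involves exchanging one halogen for another. Compound 4 `O=C1C(=O)N(CCCn2cc(COc3cc(=O)oc4ccccc34)nn2)c2ccc(Cl)cc21` differs from compound 2 by chloro in place of iodo on an aromatic carbon. For the measured compounds named here, with no comparable step to lean on, the expectation is a change no larger than the scatter. Compound 4 is therefore estimated at 62%, in the range 45% to 78%, an expected step of a number 5 percentage points lower from compound 2 to compound 4 (within the scatter).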

Compound 4, percent growth inhibition at one concentration: 78%
Compound 4: middle estimate off by 16 percentage points, on the low side; low and high end bracket the measured number.
By their numbers in this assay, from the lowest: compound 3; then compounds 2, 1 and 4 (each within the scatter of the next, the first and the last beyond it).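

In this assay, chloro in place of iodo gives a number 11 percentage points higher from compound 2 to compound 4 (beyond the scatter), so the choice of halogen on this aromatic carbon can shift the number beyond the scatter. The earlier step at this position, a number 32 percentage points lower from compound 1 to compound 3 (beyond the scatter), replaced hydrogen with nitro and lowered the number, whereas this one raises it, so a change here need not reduce growth inhibition. No measurement shown here explains the difference. Where bromo or fluoro on this carbon would fall remains open, as does whether an amine there would behave more like chloro or like nitro.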